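Trimming the phosphate-bearing chain of a bromouracil nucleotide

The source may hold more compounds than are shown below. What is called first, only, known or untested is meant among the compounds shown, and "the series" means these compounds.

Compound 2 `O=c1[nH]c(=O)n([C@@H]2O[C@H](COP(=O)(O)OP(=O)(O)OP(=O)(O)O)[C@@H](O)[C@H]2O)cc1Br` gives 3460 nM in an in vitro functional assay on 1321-N1 cells for agonist activity at P2Y purinoceptor 4 (Homo sapiens); a lower number here means that less compound is needed, a higher number that more compound is needed for the effect. Compound 1 `O=c1ccn([C@@H]2O[C@H](COP(=O)(O)OP(=O)(O)OP(=O)(O)O)[C@@H](O)[C@H]2O)c(=S)[nH]1` gives 1770 nM in this assay, and the step of a 2.0-fold higher number from compound 1 to compound 2 (0.29 log units; within the scatter) lies within the scatter, so the two numbers cannot be told apart. Compound 3 `Cc1cc(=O)n([C@@H]2O[C@H](COP(=O)(O)OP(=O)(O)OP(=O)(O)O)[C@@H](O)[C@H]2O)c(=O)[nH]1` reaches only the limit > 100000 nM in this assay. The steps of an at least 56-fold higher number from compound 1 to compound 3 (1.75 log units; beyond the scatter) and an at least 28-fold higher number from compound 2 to compound 3 (1.46 log units; beyond the scatter) are large, but every measured step alters the six-membered aromatic ring on the saturated ring carbon and leaves the chain on the oxygen whose other neighbours are phosphorus untouched. Compound 4 `O=c1[nH]c(=O)n([C@@H]2O[C@H](COP(=O)(O)O)[C@@H](O)[C@H]2O)cc1Br` differs from compound 2 by a hydrogen atom in place of a group of 8 heavy atoms (6 oxygen, 2 phosphorus; no ring), on an oxygen. No measured step bears on this change, so the expectation rests on the change itself rather than on any shown comparison. Compound 4 is expected to need far more material, a step of a 23-fold higher number from compound 2 to compound 4 (1.36 log units; beyond the scatter), and the result may well be reported only as a limit. The estimate for compound 4 is 80000 nM, within 10000 nM to 300000 nM.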

Compound 4, half-maximal effective concentration: > 100000 nM
Compound 4 was reported as a limit; the forecaster's own chance of this, stated with the estimate: 70%; middle value at least 1.2-fold (0.09 log units) away from the limit.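

This is the first change shown in the chain rather than in the six-membered aromatic ring, and it matters as much as the largest ring change. A hydrogen atom in place of the group of 8 heavy atoms on the oxygen gives an at least 28-fold higher number from compound 2 to compound 4 (1.46 log units; beyond the scatter), so in this assay the bromouracil ring of compound 2 does not keep its number without that group. The result for compound 4 is a limit of the assay, so the step has a lower bound but no end: the limit of > 100000 nM in this assay, at which 2 of the 4 values shown sit.

The compounds shown leave open whether a diphosphate chain on the same oxygen would stay near compound 2 or also reach the limit. They also leave open whether a phosphonate in that chain would be tolerated, and they give no cause for the loss.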